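A few compounds are considered here, and "the series" means these few. Any claim that something is new, unique, unknown or untested is made for them only; others in the source may bear on it.

Working notes on the chromene chalcone series.

Going by the values given here, compound 1 `COc1ccc(C(=O)/C=C/c2cccc([N+](=O)[O-])c2)c2c1C=CC(C)(C)O2` is measured in a functional assay on K562 cells (Homo sapiens) for antiproliferative activity, read by MTT assay, with a stated time of 24 h (a higher number here means a weaker inhibitor, a lower number a stronger inhibitor), and gives 5870 nM, the only concrete number in this set. Compound 2 `CCOc1cc(/C=C/C(=O)c2ccc(OC)c3c2OC(C)(C)C=C3)ccc1O` in this assay reaches only the limit of > 10000 nM, which is a limit of the assay and not a number. So compound 1 stands as the one compound with a stated value, while the second value shown is a limit (the limit of > 10000 nM in this assay, at which 1 of the 2 values shown sits). Among the compounds with values here, no step between measured compounds can be counted here, and the two values show only that compound 1 sits inside the range of this assay while compound 2 does not.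

Compound 3 `COc1ccc(C(=O)/C=C/c2cc(Cl)ccc2O)c2c1C=CC(C)(C)O2` is not yet measured. It differs from compound 1 as follows: 5-chloro-2-hydroxyphenyl in place of 3-nitrophenyl on a double-bonded chain carbon bound to a double-bonded chain carbon. With no measured step of this kind among the compounds shown, the expectation is a step no larger than the usual scatter, if anything slightly toward a weaker inhibitor, so the step from compound 1 to compound 3 is expected to be about a 1.3-fold higher number from compound 1 to compound 3 (0.11 log units; within the scatter). Compound 3 is therefore estimated at 7500 nM in this assay, within a range from 2500 nM to 22000 nM, with a real chance that only a limit is reported.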

Compound 3, half-maximal inhibitory concentration: 5510 nM
For compound 3 the middle estimate is 1.4-fold (0.13 log units) above the measured one, and the stated range covers the measured number.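

The exchange of 3-nitrophenyl for 5-chloro-2-hydroxyphenyl on a double-bonded chain carbon bound to a double-bonded chain carbon gives, in this assay, a 1.1-fold lower number from compound 1 to compound 3 (0.03 log units; within the scatter), so the two compounds cannot be told apart at this position. The change is not a small one on paper: the group that leaves has 0 hydrogen-bond donors and 2 hydrogen-bond acceptors, and the group that enters has 1 hydrogen-bond donor, 1 hydrogen-bond acceptor and a chlorine. With compound 3, the series now has two concrete numbers on the shared core, and for this pair the read-out does not follow that difference in groups.

Chlorine and hydroxy enter together and the nitro group leaves in the same step, so the share of each stays open, as does the reading for an amine or a carboxylic acid on this phenyl ring. Compound 2 remains a limit and not a number, and no step to it can be read: the limit of > 10000 nM in this assay, at which 1 of the 3 values shown sits.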